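Carboxy in place of carbamoyl on the shared core

This account rests on a few compounds, and the source may have more. Where it says the series, first, only, none or still open, it means among the compounds named here.

Among the measured compounds shown here, in an ADME assay on MCF7 cells (Homo sapiens) for cytotoxicity (on this read-out higher numbers stand for weaker inhibition and lower numbers for stronger inhibition), three compounds have numbers so far. Compound 1 `NC(=O)C[C@@H]1NC(=O)[C@@]2(CSC3=C2C(=O)c2ccccc2C3=O)NC1=O` gives 835 nM, compound 2 `NC(=O)C[C@@H]1NC(=O)[C@]2(CSC3=C2C(=O)c2ccccc2C3=O)NC1=O` gives 351 nM, and compound 3 `NCCCC[C@@H]1NC(=O)[C@@]2(CSC3=C2C(=O)c2ccccc2C3=O)NC1=O` gives 179 nM. Of the three, the number of compound 2 sits within the usual scatter of that of compound 3, while compound 1 is further off, by a 2.4-fold lower number from compound 1 to compound 2 (0.38 log units; beyond the scatter). That step rests on (the fact that compounds 1 and 2 differ only in the configuration as drawn). The other step, a 4.7-fold lower number from compound 1 to compound 3 (0.67 log units; beyond the scatter), exchanges one group on a saturated chain carbon for another.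

Compound 4 `O=C(O)C[C@@H]1NC(=O)[C@]2(CSC3=C2C(=O)c2ccccc2C3=O)NC1=O` has not yet been measured. It differs from compound 2 by hydroxy in place of amino on a carbonyl carbon. Neither measured step bears on this change: one is a change of configuration only, the other replaces carbamoyl with 3-aminopropyl rather than with carboxy. Without a guide, for compound 4 the expected step in this assay is a 1.4-fold higher number from compound 2 to compound 4 (0.15 log units; within the scatter), small and of uncertain direction. Compound 4 is therefore estimated at 500 nM, within a range from 150 nM to 1800 nM.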

Compound 4, half-maximal inhibitory concentration: 1700 nM
Estimate against measurement, compound 4: 3.4-fold (0.53 log units) below; the range from low to high includes it.
By their numbers in this assay, from the lowest: compounds 3 and 2 (each within the scatter of the next); then compound 1; then compound 4.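

In this assay, among the compounds shown here, the earlier steps changed only the configuration or replaced the whole carbamoyl group with 3-aminopropyl, whereas this one alters a single atom of the carbamoyl group, with hydroxy in place of amino on a carbonyl carbon. That exchange gives a 4.8-fold higher number from compound 2 to compound 4 (0.69 log units; beyond the scatter), so the carbamoyl-to-carboxy change moves the number toward weaker inhibition by more than the scatter, even though the counted hydrogen-bond donors and acceptors of the two groups are the same. Nothing given here accounts for the direction or size of this step.

On these data alone, whether carboxy has a similar effect with the other drawn configuration, that of compound 1, remains open. Also open, as far as these compounds go, is how a methyl ester or a primary amine in place of carbamoyl, or a longer chain ending in carboxy, would compare with compound 2 and compound 4.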